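Working notes on the shared core: from compound 2 to compound 3

This account rests on a few compounds, and the source may have more. Where it says the series, first, only, none or still open, it means among the compounds named here.

Compound 1 `CCCCCCCCc1ccc(OCC(=O)Cn2nnc(SC)n2)cc1` and compound 2 `CCCCCCCCc1ccc(OCC(=O)Cn2nnc(-c3ccc(S(=O)(=O)N(C)C)cc3)n2)cc1` share one core. In an ADME assay on S9 fraction from liver (Rattus norvegicus) for metabolic stability, read by LC-MS, using NADPH, with a stated time of 30 min (on this read-out lower numbers stand for a less stable compound and higher numbers for a more stable compound), compound 1 gives only a limit, < 5%. In this assay compound 2 gives 65%, the only number shown; of the two values shown, one sits at the limit of < 5% in this assay, at which 1 of the 2 values shown sits. Among the compounds with values here, the single measured step is a number at least 60 percentage points higher from compound 1 to compound 2 (beyond the scatter).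

Compound 3 `CCCCCCCCc1ccc(OCC(=O)Cn2nnc(CCC(=O)O)n2)cc1` is not yet measured. It differs from compound 2 by 2-carboxyethyl in place of 4-(dimethylsulfamoyl)phenyl on an aromatic carbon. Within the data shown here, the measured step removed methylsulfanyl and entered 4-(dimethylsulfamoyl)phenyl; the present step removes that same group, so no measured step bears directly on it and no direction can be taken from it. A downward step is expected, a number 30 percentage points lower from compound 2 to compound 3 (beyond the scatter). Compound 3 is thus estimated at 35%, within 10% to 70%.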

Compound 3, percent of the compound remaining: < 5%
Compound 3 gave a limit, no number (the forecaster's own chance of this, stated with the estimate: 15%); at least 30 percentage points between middle value and limit.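

In this assay, 2-carboxyethyl in place of 4-(dimethylsulfamoyl)phenyl gives a number at least 60 percentage points lower from compound 2 to compound 3 (beyond the scatter). At this position, then, replacing methylsulfanyl does not by itself give a value like that of compound 2: the result depends on which group enters. The step from compound 1 to compound 3 cannot be read, because both values are limits: the limit of < 5% in this assay, at which 2 of the 3 values shown sit.

On these data alone, with only compound 2 giving a number, it remains open whether a plain phenyl would keep that value or the dimethylsulfamoyl group is needed. Also open, as far as these compounds go, is how an ester or amide of the carboxylic acid would read out.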